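The source may hold more compounds than are shown below. What is called first, only, known or untested is meant among the compounds shown, and "the series" means these compounds.

Measured so far:
Compound 1 `COc1ccc(C(c2ccc(OCCO)cc2)c2cccc3ccccc23)c(OC)c1OC` — in a functional assay on A549 cells (Homo sapiens) for inhibition, read by sulforhodamine B assay, with a stated time of 48 h (a higher number here means a weaker inhibitor, a lower number a stronger inhibitor), compound 1 returns only the limit > 20000 nM, not a number.
Compound 2 `COc1ccc(C(c2ccc(OCC(=O)O)cc2)c2cccc3ccccc23)c(OC)c1OC` — in this assay compound 2 gives 16400 nM.

Within the data shown here, compound 2 thus holds the only numerical value in this assay; the other result is a limit (the limit of > 20000 nM in this assay, at which 1 of the 2 values shown sits). Among the measured compounds shown here, the single measured step, an at least 1.2-fold lower number from compound 1 to compound 2 (0.08 log units; that floor lies within the scatter), concerns the carboxy group on the chain alone. Compound 3 `C=CCOC(c1ccc(OC)c(OC)c1OC)c1cccc2ccccc12` departs from compound 2 far more broadly: allyloxy in place of 4-(carboxymethoxy)phenyl on a saturated chain carbon bound to two aromatic carbons. No measured step touches an exchange at a saturated chain carbon bound to two aromatic carbons, so the one step in hand offers no guide to the direction of this change, and no step in this assay beyond the scatter can be anticipated from what is shown. Compound 3 is therefore estimated at 18000 nM, between 6000 nM and 40000 nM, with a real chance that only a limit is returned. The expected step is a 1.1-fold higher number from compound 2 to compound 3 (0.04 log units; within the scatter), meaning no movement beyond the scatter.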

Compound 3, half-maximal inhibitory concentration: 9710 nM
Beside the measured number, compound 3's estimate is 1.9-fold (0.27 log units) above it; the measured number falls inside the stated range.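

In this assay, among these compounds, the saturated chain carbon bound to two aromatic carbons is now seen to change for the first time: allyloxy in place of 4-(carboxymethoxy)phenyl gives a 1.7-fold lower number from compound 2 to compound 3 (0.23 log units; within the scatter). The larger group, with its aromatic ring and its carboxy end, can therefore be exchanged for the ring-free allyloxy with no movement beyond the scatter. Measured against the 4-(2-hydroxyethoxy)phenyl group, the same kind of exchange gives an at least 2.0-fold lower number from compound 1 to compound 3 (0.31 log units; beyond the scatter), the only step shown that passes the scatter, and its size is only a floor, set by a limit: the limit of > 20000 nM in this assay, at which 1 of the 3 values shown sits.

On these data alone, whether a propoxy chain, a longer ether chain or an amine at this carbon would do the same as allyloxy stays open. So does any change to the shared core, which is the same in all three compounds.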